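The compounds below may be only part of what the source reports. "The series", "measured", "known", "first", "only" and "open" are said of these compounds alone.

Measured so far:
compound 1, `Cc1ccccc1CN1CCc2c(sc(NC(=O)c3ccccc3Cl)c2C(N)=O)C1`: > 50000 nM
compound 2, `NC(=O)c1c(NC(=O)c2ccccc2Cl)sc2c1CCN(Cc1ccc(Cl)cc1)C2`: 18700 nM
compound 3, `CSc1ccccc1NC(=S)N1CCc2c(sc(NC(=O)c3ccccc3Cl)c2C(N)=O)C1`: 13800 nM

In a functional assay on MKN-74 cells (Homo sapiens) for antiproliferative activity, with a stated time of 24 h (a lower number here means a stronger inhibitor, a higher number a weaker inhibitor), compound 1 gives > 50000 nM, which is a limit of the assay and not a number (the limit of > 50000 nM in this assay, at which 1 of the 3 values shown sits). From there the series moves to compound 4, `NC(=O)c1c(NC(=O)c2ccccc2Cl)sc2c1CCN(C(=S)Nc1cccnc1)C2`, where the change is a group of 9 heavy atoms (6 carbon, 2 nitrogen, 1 sulfur; one six-membered aromatic ring with 1 hetero atom) in place of a group of 8 heavy atoms (8 carbon; one six-membered aromatic ring of carbon only), on an amine nitrogen in a ring. Two measured steps start from the same point: an at least 2.6-fold lower number from compound 1 to compound 2 (0.42 log units; beyond the scatter), and an at least 3.6-fold lower number from compound 1 to compound 3 (0.55 log units; beyond the scatter). The step from compound 2 to compound 3, a 1.4-fold lower number from compound 2 to compound 3 (0.13 log units; within the scatter), adds little. Compound 3 carries the closest analogue of the group that enters compound 4, so a lower number is expected, of about the size seen for compound 3: an at least 2.5-fold lower number from compound 1 to compound 4 (0.39 log units; beyond the scatter). Compound 4 is therefore estimated at 20000 nM, within 7000 nM to 60000 nM.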

Compound 4, half-maximal inhibitory concentration: 38600 nM
Beside the measured number, compound 4's estimate is 1.9-fold (0.29 log units) below it, within the range that was stated.
By their numbers in this assay, from the lowest: compounds 3 and 2 (each within the scatter of the next); then compound 4. At a limit, above all of these: compound 1.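

In this assay, pyridin-3-yl in place of 2-(methylsulfanyl)phenyl on an amide-type nitrogen gives a 2.8-fold higher number from compound 3 to compound 4 (0.45 log units; beyond the scatter). Going by these compounds alone, the group in compound 4 also compares unfavourably with the one in compound 2, with a 2.1-fold higher number from compound 2 to compound 4 (0.31 log units; beyond the scatter). The value of compound 1 is a limit of the assay and not a number: the limit of > 50000 nM in this assay, at which 1 of the 4 values shown sits. Only a floor can be stated for this step, an at least 1.2-fold lower number from compound 1 to compound 4 (0.11 log units; that floor lies within the scatter).

Whether the pyridine nitrogen or the missing methylsulfanyl group accounts for the higher number stays open. So does the effect of a plain phenyl on that nitrogen, or of a carbonyl in place of the thiocarbonyl.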